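A few compounds are considered here, and "the series" means these few. Any claim that something is new, unique, unknown or untested is made for them only; others in the source may bear on it.

Of the compounds shown here, three have been measured in a functional assay on CHO cells for positive allosteric modulation of metabotropic glutamate receptor 2 (Homo sapiens), with a stated time of 30 min; a higher number here means that more compound is needed for the effect, a lower number that less compound is needed. Compound 3 `N#Cc1c(N2CCC(c3ccc(F)cc3)CC2)ccn(CC2CC2)c1=O` gives 89 nM and shows the lowest number of the three. Compound 1 `CC(C)CCn1ccc(N2CCCC(c3ccccc3)C2)c(C#N)c1=O` gives 3310 nM, and compound 2 `CC(C)CCn1ccc(N2CCCCC2)c(C#N)c1=O` gives 31600 nM, the highest number in the set. For the measured compounds named here, the one step that links two measured compounds, a 9.5-fold higher number from compound 1 to compound 2 (0.98 log units; beyond the scatter), concerns the loss of the whole phenyl from a saturated ring carbon; it shows that the aryl on that carbon matters, but says nothing about how a fluorine pattern on the aryl changes the number.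

Compound 4 `N#Cc1c(N2CCC(c3cc(F)cc(F)c3)CC2)ccn(CC2CC2)c1=O` is the unmeasured compound. It differs from compound 3 in one place: 3,5-difluorophenyl in place of 4-fluorophenyl on a saturated ring carbon. Both groups keep the same six-membered aromatic ring of carbon only, with no hydrogen-bond donors or acceptors and no net charge; only the count and placement of fluorine changes. Going by the values given here, no measured step in this assay covers a change of this kind, so no direction can be read from the data, and a step within the scatter is the most reasonable expectation for the step from compound 3 to compound 4, as a 1.2-fold higher number from compound 3 to compound 4 (0.09 log units; within the scatter) expresses. Compound 4 is therefore expected to give about 110 nM in this assay, with a plausible range from 35 nM to 350 nM.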

Compound 4, half-maximal effective concentration: 151 nM
Compound 4: the middle estimate sits 1.4-fold (0.14 log units) below what was measured, within the range that was stated.
By their numbers in this assay, from the lowest: compounds 3 and 4 (each within the scatter of the next); then compound 1; then compound 2.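

In this assay, replacing 4-fluorophenyl with 3,5-difluorophenyl on the saturated ring carbon, three ring bonds from the ring nitrogen, gives a 1.7-fold higher number from compound 3 to compound 4 (0.23 log units; within the scatter) and so does not move the number outside the usual variation between repeats. The earlier step, a 9.5-fold higher number from compound 1 to compound 2 (0.98 log units; beyond the scatter) when the whole phenyl is lost, showed only that having an aryl on a saturated ring carbon matters, while this pair shows that, with the aryl kept, a second fluorine and a new fluorine placement can be accepted at this position without a clear loss. Nothing measured in this set bears on why the two fluorinated aryl groups give numbers this close.

One pair cannot show whether fluorine is needed at all, since a bare phenyl on the core of compound 3 is not among the compounds shown. It also leaves open whether a larger or different substituent on this aryl, such as a methoxy group or a chlorine, or a pyridine ring in place of the phenyl, would stay this close to compound 3.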